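Methoxy in Place of Hydrogen on an Inactive Benzyl Series

This account rests on a few compounds, and the source may have more. Where it says the series, first, only, none or still open, it means among the compounds named here.

Compound 3 `O=c1ccoc2cc(OCc3cn(Cc4ccccc4)nn3)ccc12` carries a benzyl group on the shared core. In a functional assay on HeLa cells (Homo sapiens) for cytotoxicity, read by MTT assay, with a stated time of 48 h (a lower number here means a stronger inhibitor, a higher number a weaker inhibitor), compound 3 gives only the limit of the assay, > 100000 nM, and no number. Compound 1 `Cc1cccc(Cn2cc(COc3ccc4c(=O)ccoc4c3)nn2)c1` gives > 100000 nM in this assay, again a limit rather than a number. Compound 2 `Cc1ccc(Cn2cc(COc3ccc4c(=O)ccoc4c3)nn2)cc1` gives > 100000 nM in this assay, once more a limit. The steps a step that the two limits leave unreadable from compound 1 to compound 2, a step that the two limits leave unreadable from compound 1 to compound 3 and a step that the two limits leave unreadable from compound 2 to compound 3 therefore cannot be sized, and the limit of > 100000 nM in this assay, at which 3 of the 3 values shown sit, shows that every value gathered so far sits at that limit. Compound 4 `COc1ccc(Cn2cc(COc3ccc4c(=O)ccoc4c3)nn2)cc1` is the unmeasured member of the set; it differs from compound 3 by methoxy in place of hydrogen on an aromatic carbon. Among the compounds with values here, no measured step involves a methoxy group, and the steps that do exist are unreadable, so nothing in the data points to a change in either direction. Compound 4 is expected to stand at the limit as its three relatives do, with an expected step that the limit leaves unreadable from compound 3 to compound 4 in this assay. The estimate for compound 4 in this assay is 150000 nM, within 40000 nM to 500000 nM, and the assay is most likely to report only a limit again.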

Compound 4, half-maximal inhibitory concentration: 14400 nM
Compound 4: middle estimate off by 10-fold (1.02 log units), on the high side, outside the stated range (below it).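

Methoxy in place of hydrogen on the aromatic carbon para to a large group gives the first readable change in this assay, an at least 6.9-fold lower number from compound 3 to compound 4 (0.84 log units; beyond the scatter), and so shows that this position of the benzyl group can alter the read-out. The change also depends on what enters, since a methyl group at the same place gave nothing readable, whereas methoxy in place of that methyl gives an at least 6.9-fold lower number from compound 2 to compound 4 (0.84 log units; beyond the scatter), and 4-methoxyphenyl in place of 3-methylphenyl gives an at least 6.9-fold lower number from compound 1 to compound 4 (0.84 log units; beyond the scatter). The steps among the three earlier compounds cannot be read, these new steps give only a lower bound on their size, and compound 4 alone has left the limit: the limit of > 100000 nM in this assay, at which 3 of the 4 values shown sit.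

The compounds shown leave open whether a hydroxyl, an ethoxy or an amine on that same aromatic carbon would lower the number further, match methoxy or leave the value at the limit. They also leave open the true size of the three new steps and whether methoxy would have any readable effect on another carbon of the ring.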